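Trimethoxyphenyl pyrazolyl chalcones: one methoxy removed

The compounds below may be only part of what the source reports. "The series", "measured", "known", "first", "only" and "open" are said of these compounds alone.

Measured values in a functional assay on SK-MEL-5 cells (Homo sapiens) for cytotoxicity, read by sulforhodamine B assay, with a stated time of 48 h, tested at 0.1 uM; on this read-out lower numbers stand for a stronger effect and higher numbers for a weaker effect at the one concentration tested:

compound 1 `COc1cc(-c2cc(/C=C/C(=O)c3ccc(N)cc3)[nH]n2)cc(OC)c1OC` gives 95%
compound 2 `COc1ccc(-c2cc(/C=C/C(=O)c3ccc(N)cc3)[nH]n2)cc1OC` gives 95%
compound 3 `COc1cc(C(=O)/C=C/c2cc(-c3cc(OC)c(OC)c(OC)c3)n[nH]2)cc(OC)c1OC` gives 95%

Compound 1 and compound 2 share a core and differ in one place: hydrogen in place of methoxy on an aromatic carbon. The step of no change at the digits printed from compound 1 to compound 2 (within the scatter) lies within the scatter, so the two values of compound 1 and compound 2 cannot be told apart in this assay. Compound 3 carries the same kind of aminophenyl-free arrangement on a different core; how the core of compound 3 differs from the core of compound 1 is not broken down here. Its value sits level with those of compound 1 and compound 2, and no order among the three can be read from these numbers.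

Compound 4 `COc1ccc(-c2cc(/C=C/C(=O)c3cc(OC)c(OC)c(OC)c3)[nH]n2)cc1OC` is not yet measured. It stands to compound 3 as compound 2 stands to compound 1: hydrogen in place of methoxy on an aromatic carbon. The place of the change is the same word for word in both pairs, so the change is the same one, made on a different core. Among the compounds with values here, the only measured instance of this change is the step from compound 1 to compound 2, which is within the scatter, and compound 3 already sits where compound 1 and compound 2 do. On that ground the step from compound 3 to compound 4 is expected to be a number 1 percentage points lower from compound 3 to compound 4 (within the scatter), that is, essentially no movement. In this assay compound 4 is therefore estimated at 94%, with a plausible range from 84% to 100%.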

Compound 4, a percentage reported as activity, at one concentration (the size of the read-out at that concentration, not a potency): 102%
Beside the measured number, compound 4's estimate is 8 percentage points below it, outside the stated range (above it).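

In this assay, within the data shown here, hydrogen in place of methoxy on an aromatic carbon gives a number 7 percentage points higher from compound 3 to compound 4 (within the scatter), so the second core offers no step that can be told apart from repeat measurements. Set beside the earlier pair, the two instances of the change do not differ: the same change on two cores in this assay, no change at the digits printed (within the scatter) from compound 1 to compound 2 and a number 7 percentage points higher (within the scatter) from compound 3 to compound 4, 7 percentage points apart, within the scatter of two such steps

Among these compounds, as far as this read-out goes, the change carries from the core of compound 1 to the core of compound 3 without a detectable difference, but this rests on only two pairs, neither with a step beyond the scatter, and it does not show that the change is without consequence on either core under other conditions: a read-out at one concentration in one cell line is not a potency, and it gives no measure of how either pair would compare at other concentrations.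

The compounds shown leave open how either core would read with a hydroxy group, a fluorine atom or a longer chain such as ethoxy at the place of the methoxy. They also leave open whether a carboxylic acid or an amide elsewhere on these cores would bring any step beyond the scatter in this assay.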